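The source may hold more compounds than are shown below. What is called first, only, known or untested is meant among the compounds shown, and "the series" means these compounds.

Compound 1, `Cc1cc(NC(=O)Nc2ccc([N+](=O)[O-])c(C(F)(F)F)c2)c2ccccc2n1`: > 25000 nM
Compound 2, `Cc1cc(NC(=O)Nc2ccc(C(=O)O)cc2)c2ccccc2n1`: > 25000 nM
Compound 3, `Cc1cc(NC(=O)Nc2cccc(C(N)=O)c2)c2ccccc2n1`: > 25000 nM

Three compounds built on the shared core were tested in an ADME assay on Raji cells (Homo sapiens) for cytotoxicity, with a stated time of 72 h; a higher number here means that more compound is needed for the effect, a lower number that less compound is needed. For compound 1 the value > 25000 nM is a limit of the assay rather than a number. For compound 2 the value > 25000 nM is likewise only a limit. For compound 3 the value > 25000 nM is again a limit. Compound 2 therefore stands where the other two stand: the limit of > 25000 nM in this assay, at which 3 of the 3 values shown sit. For the measured compounds named here, no step between two measured compounds can be drawn from these three, since each gives a limit and no number.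

Compound 4, `Cc1cc(NC(=O)Nc2ccc(F)cc2)c2ccccc2n1`, differs from compound 2 in one place: fluoro in place of carboxy on an aromatic carbon. Going by the values given here, with nothing but limits around compound 2, no step in this assay beyond the usual scatter is expected. Compound 4 is accordingly estimated at 30000 nM, within 10000 nM to 100000 nM, most likely reported once more as a limit, which means an expected step that the limit leaves unreadable from compound 2 to compound 4 of no real size.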

Compound 4, half-maximal effective concentration: > 25000 nM
Compound 4 ended at the assay's limit (the forecaster's own chance of this, stated with the estimate: 75%); the middle value does not contradict the limit.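

For the compounds shown here, compound 2 and compound 4 each give only a limit in this assay, and no step between them can be read. The compounds shown leave open what concentration of any of them would give the half-maximal effect: the limit of > 25000 nM in this assay, at which 4 of the 4 values shown sit.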